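The source may report more compounds than this note shows. Statements on the series, on what has been measured and on what is new or still open speak of the compounds shown alone.

Measured in a functional assay on the whole organism (strain Sprague-Dawley) for inhibition, with Rattus norvegicus as the target, read by paw edema, with stated times of 1 h and 3 h, at a dose of 50 mg/kg by the oral route; on this read-out higher numbers stand for more inhibition at the one dose given (going by the name of the read-out) and lower numbers for less inhibition:
compound 1 `Cc1ccc2ncc(C(=O)c3sc(N)nc3N(C)C)n2c1` gives 23%;
compound 2 `Cc1ccc2ncc(C(=O)c3sc(N)nc3-c3ccccc3)n2c1` gives 77%;
compound 3 `Cc1nc(N)sc1C(=O)c1cnc2ccccn12` gives 53%.

Compound 3 stands second highest of the three numbers in this assay: compound 2 stands higher by a gap beyond the scatter, compound 1 lower, also beyond the scatter.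

Compound 4 `Cc1ccc2ncc(C(=O)c3sc(N)nc3C)n2c1` differs from compound 3 by methyl in place of hydrogen on an aromatic carbon, the new methyl sitting on an aromatic carbon of a six-membered aromatic ring with one nitrogen, part of a fused system of two rings. Going by the values given here, the only measured step, a number 54 percentage points higher from compound 1 to compound 2 (beyond the scatter), concerns phenyl in place of dimethylamino on the other ring and does not bear on this change. Among the compounds with values here, compounds 1 and 2 carry the methyl on the six-membered ring but differ from compound 3 elsewhere too, so no measured step isolates it. No step beyond the scatter is therefore expected in this assay; the expected step is a number 2 percentage points higher from compound 3 to compound 4 (within the scatter). Compound 4 is estimated at 55%, within 35% to 75%.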

Compound 4, a percentage reported as inhibition, in the whole organism at one dose (the size of the read-out at that dose, not a potency): 33%
Compound 4: middle estimate off by 22 percentage points, on the high side, outside the stated range (below it).
By their numbers in this assay, from the lowest: compounds 1 and 4 (each within the scatter of the next); then compound 3; then compound 2.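

In this assay the position on the six-membered aromatic ring is not silent: methyl in place of hydrogen there gives a number 20 percentage points lower from compound 3 to compound 4 (beyond the scatter). With that methyl kept, methyl in place of phenyl on the other ring gives a number 44 percentage points lower from compound 2 to compound 4 (beyond the scatter) and methyl in place of dimethylamino gives a number 10 percentage points higher from compound 1 to compound 4 (within the scatter), so of these three groups only phenyl stands apart. Nothing at hand accounts for these steps.

Open, going by these compounds, is whether chlorine or methoxy at the same position would act as methyl does. Also open, on these data alone, is what hydrogen there would give with phenyl on the other ring.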